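The compounds below may be only part of what the source reports. "The series", "measured", "known", "first", "only" and "open" are said of these compounds alone.

Working notes on the series, read in a functional assay on MCF7 cells (Homo sapiens) for cytotoxicity, read by MTT assay, with a stated time of 72 h; a higher number here means a weaker inhibitor, a lower number a stronger inhibitor. Compound 1 (`CNC(=O)c1cc(Oc2ccc(C(=O)/C=C/c3ccc(OC)c(OC)c3OC)cc2)ccn1`) gives 2910 nM, and compound 3 (`CNC(=O)c1cc(Oc2ccc(C(=O)/C=C/c3cc(OC)c(OC)c(OC)c3)cc2)ccn1`) gives 3880 nM. Compound 2 (`CNC(=O)c1cc(Oc2ccc(C(=O)/C=C/c3ccc(F)cc3Cl)cc2)ccn1`) gives 21100 nM, the highest number of the three and the weakest inhibitor here, beyond the scatter against each of the other two.

Compound 4 (`CNC(=O)c1cc(Oc2ccc(C(=O)/C=C/c3ccc(Cl)cc3Cl)cc2)ccn1`) has not yet been measured. It differs from compound 2 as follows: chloro in place of fluoro on an aromatic carbon. The new chloro group stands meta to a chloro group and para to a large group. For the measured compounds named here, no measured pair isolates this change, so the series gives no direct guide to its size or direction. Going by the values given here, the anchor is therefore compound 2 at 21100 nM, the only measured compound with a chloro group.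

In this assay, a small shift toward a lower number is expected, and it may not exceed the scatter. The estimated step is a 1.5-fold lower number from compound 2 to compound 4 (0.18 log units; within the scatter). Compound 4 is expected at 14000 nM, with an estimated range of 5500 nM to 35000 nM.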

Compound 4, half-maximal inhibitory concentration: 3990 nM
Estimate against measurement, compound 4: 3.5-fold (0.55 log units) above; the whole stated range lies above it.
By their numbers in this assay, from the lowest: compounds 1, 3 and 4 (each within the scatter of the next); then compound 2.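

In this assay, for the compounds shown here, the change from 2-chloro-4-fluorophenyl to 2,4-dichlorophenyl gives a 5.3-fold lower number from compound 2 to compound 4 (0.72 log units; beyond the scatter), the first measured step for chloro in place of fluoro at this position, para to a large group and meta to a chloro group. This shows that the exchange of one heavy atom on the aromatic carbon is enough to move the number beyond the scatter, with the ring, the hydrogen-bond donor and acceptor counts and the net charge unchanged. Nothing at hand bears on what lies behind this step.

The compounds shown leave open how a bromo or methyl group would read at this position. They also leave open whether the same exchange gives a step of this size when no chloro group stands meta to it.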